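The compounds below may be only part of what the source reports. "The series", "measured", "known", "first", "only" and "open" are said of these compounds alone.

Measured so far in a functional assay on NCI-H460 cells (Homo sapiens) for inhibition, read by sulforhodamine B assay, with a stated time of 48 h; on this read-out lower numbers stand for higher toxicity in this test and higher numbers for lower toxicity in this test:
compound 1 `O=C(Nc1cccc(-n2cc(-c3ccncc3)c(-c3ccc(Cl)c(O)c3)n2)c1)Nc1cccc(C(F)(F)F)c1`, > 32500 nM;
compound 2 `COc1cc(-c2nn(-c3cccc(NC(=O)c4cccc(C(F)(F)F)c4)c3)cc2-c2ccncc2)ccc1Cl`, > 50000 nM;
compound 3 `O=C(Nc1cccc(-n2cc(-c3ccncc3)c(-c3ccc(Cl)c(O)c3)n2)c1)Nc1ccc(Cl)c(Cl)c1`, 24200 nM.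

Compound 2 stands at a limit of this assay, not at a measured number: its value of > 50000 nM is the limit (the limit of > 50000 nM in this assay, at which 1 of the 3 values shown sits). Compound 1 likewise sits at a limit, (the limit of > 32500 nM in this assay, at which 1 of the 3 values shown sits). Only compound 3 gives a number, and the step of an at least 1.3-fold lower number from compound 1 to compound 3 (0.12 log units; that floor lies within the scatter) lies within the scatter.

Compound 4 `COc1cc(-c2nn(-c3cccc(NC(=O)Nc4cccc(C(F)(F)F)c4)c3)cc2-c2ccncc2)ccc1Cl` differs from compound 2 by (3-(trifluoromethyl)phenyl)amino in place of 3-(trifluoromethyl)phenyl on a carbonyl carbon. Among the compounds with values here, none of the measured steps covers this change; the one step known, from compound 1 to compound 3, concerns a different group on the amide-type nitrogen. What the numbers show is that compound 3, a urea, and compound 1, a urea, are both weak in this assay, and that compound 2, an amide, is at a limit. No step beyond the scatter is therefore expected for an at least 1.1-fold lower number from compound 2 to compound 4 (0.04 log units; that floor lies within the scatter). Compound 4 is estimated at 45000 nM, between 18000 nM and 120000 nM, with a real chance that only a limit is reported.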

Compound 4, concentration lethal to 50% of the cells: > 50000 nM
Compound 4 gave a limit, no number (the forecaster's own chance of this, stated with the estimate: 65%); at least 1.1-fold (0.04 log units) between middle value and limit.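

In this assay compound 4 gives > 50000 nM, which is a limit and not a number. The steps to compound 4 from compound 2 and from compound 1 cannot be read, with limits at both ends. The compounds shown leave open whether either change alters toxicity in this assay.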